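The compounds below may be only part of what the source reports. "The series", "measured", "known", "first", "only" and "open" are said of these compounds alone.

Of the compounds shown here, three built on a shared core have been read in an ADME assay on L1210/0 cells (Mus musculus) for cytotoxicity, with a stated time of 48 h (on this read-out lower numbers stand for stronger inhibition and higher numbers for weaker inhibition), and they differ only in the group on one aromatic carbon. Compound 1 `O=c1[nH]c(=O)n([C@H]2C[C@H](O)[C@@H](CO)O2)cc1/C=N/O` gives 15500 nM, and compound 2 `O=C(CI)NCc1cn([C@H]2C[C@H](O)[C@@H](CO)O2)c(=O)[nH]c1=O` gives 107000 nM. Compound 3 `O=c1[nH]c(=O)n([C@H]2C[C@H](O)[C@@H](CO)O2)cc1C#CCCCO` gives > 200000 nM, which is a limit and not a number. Its standing in the series is therefore only (the limit of > 200000 nM in this assay, at which 1 of the 3 values shown sits).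

Compound 4 `CS(=O)(=O)Cc1cn([C@H]2C[C@H](O)[C@@H](CO)O2)c(=O)[nH]c1=O` carries (methylsulfonyl)methyl in place of the 5-hydroxypent-1-yn-1-yl of compound 3, on the same aromatic carbon: (methylsulfonyl)methyl in place of 5-hydroxypent-1-yn-1-yl on an aromatic carbon. All three measured steps change this one group. The step of a 6.9-fold higher number from compound 1 to compound 2 (0.84 log units; beyond the scatter) is modest, and the step of an at least 12-fold higher number from compound 1 to compound 3 (1.11 log units; beyond the scatter) is large. The step of an at least 1.8-fold higher number from compound 2 to compound 3 (0.27 log units; that floor lies within the scatter) has a floor that lies within the scatter, so it separates nothing. Only compound 1, at 15500 nM, stands clearly apart, and its oxime-bearing group does not return in compound 4. Compound 4 is therefore expected to stay in the weak range with compound 2, at 107000 nM. The expected change is small and toward a lower number, and it may not exceed the scatter: an at least 1.4-fold lower number from compound 3 to compound 4 (0.15 log units; that floor lies within the scatter). For compound 4 the estimated value is 140000 nM, with an expected range from 50000 nM to 300000 nM.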

Compound 4, half-maximal inhibitory concentration: > 200000 nM
Compound 4 was reported as a limit; the forecaster's own chance of this, stated with the estimate: 45%; at least 1.4-fold (0.15 log units) between middle value and limit.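

In this assay compound 4 gives > 200000 nM, which is a limit and not a number, so the step from compound 3 cannot be read, as neither compound has an exact value. Two quite different groups on this aromatic carbon, the 5-hydroxypent-1-yn-1-yl with its triple bond and the (methylsulfonyl)methyl with its two double bonds, now end at the same limit of the assay: the limit of > 200000 nM in this assay, at which 2 of the 4 values shown sit. Of the steps that can be read, the comparison with the oxime-bearing group gives an at least 12-fold higher number from compound 1 to compound 4 (1.11 log units; beyond the scatter), which confirms for a second group how far compound 1 stands apart, whereas the comparison with the iodine-bearing group gives only an at least 1.8-fold higher number from compound 2 to compound 4 (0.27 log units; that floor lies within the scatter), so that step does not set those two compounds apart.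

From the compounds shown here alone, whether compound 3 and compound 4 truly differ stays open, as does how far either lies past the limit. Going by these compounds, it is also open whether a small group such as an amine or a carboxylic acid on this aromatic carbon would read closer to compound 1 or would also end at the limit.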